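Cytotoxicity of the thiocarbamate series: pyridine regioisomer

The source may hold more compounds than are shown below. What is called first, only, known or untested is meant among the compounds shown, and "the series" means these compounds.

Among the compounds with values here, compound 1 `Cc1ccc(NC(=S)OCCc2ccccn2)cc1` is the one member of the series with a numerical value in an ADME assay on MT4 cells (Homo sapiens) for cytotoxicity, read by MTT assay; a lower number here means that less compound is tolerated, a higher number that more compound is tolerated; compound 1 gives 75000 nM. Compound 2 `Fc1ccc(NC(=S)OCCc2ccccn2)cc1` reaches only a limit in this assay, reported as > 100000 nM. Compound 3 `O=[N+]([O-])c1ccc(NC(=S)OCCc2ccccn2)cc1` likewise reaches only a limit in this assay, reported as > 100000 nM. The step of an at least 1.3-fold higher number from compound 1 to compound 2 (0.12 log units; that floor lies within the scatter) and the step of an at least 1.3-fold higher number from compound 1 to compound 3 (0.12 log units; that floor lies within the scatter) are therefore floors, and the step that the two limits leave unreadable from compound 2 to compound 3 cannot be read at all, as noted in the limit of > 100000 nM in this assay, at which 2 of the 3 values shown sit.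

Compound 4 `Cc1ccc(NC(=S)OCCc2ccncc2)cc1` differs from compound 1 by pyridin-4-yl in place of pyridin-2-yl on a saturated chain carbon, two bonds along the chain from an oxygen on an unsaturated carbon. Within the data shown here, none of the measured steps touches this part of the shared core; all three vary the substituent on the aromatic carbon of the aniline side. Among the measured compounds shown here, no measured step thus bears on the change from compound 1 to compound 4, and no step beyond the scatter in this assay is expected from it, so compound 4 is estimated at 75000 nM, within 35000 nM to 160000 nM, meaning an expected step of no change at the digits printed from compound 1 to compound 4 (within the scatter).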

Compound 4, half-maximal cytotoxic concentration: > 100000 nM
Compound 4: a limit, no number; the forecaster's own chance of this, stated with the estimate: 40%; middle value at least 1.3-fold (0.12 log units) away from the limit.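

Within the data shown here, the change from pyridin-2-yl to pyridin-4-yl is the first to touch the chain side of the shared core, and it gives an at least 1.3-fold higher number from compound 1 to compound 4 (0.12 log units; that floor lies within the scatter). In this assay, on these data alone, compound 4 reaches only a limit, > 100000 nM, so the true size of this step remains unknown. Among these compounds, compound 1 thus remains the only member with a numerical value, and the series gives little room for comparison at this position or on the aromatic carbon of the aniline side: the limit of > 100000 nM in this assay, at which 3 of the 4 values shown sit.

As far as these compounds go, whether pyridin-3-yl or plain phenyl on the same chain carbon, or a longer chain between the oxygen and the ring, would give a numerical value remains open. The step between compound 2 and compound 3 still cannot be read.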